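The source may hold more compounds than are shown below. What is called first, only, known or untested is meant among the compounds shown, and "the series" means these compounds.

The measured compounds are these. Compound 1 `ClCc1ccc(Cn2cnc3c(Cl)ncnc32)cc1` gives in a functional assay on SK-MEL-2 cells (Homo sapiens) for cytotoxicity, read by sulforhodamine B assay, with a stated time of 48 h (on this read-out lower numbers stand for higher toxicity in this test and higher numbers for lower toxicity in this test), a value of > 100000 nM, which is a limit of the assay. Compound 2 `ClCc1cccc(Cn2cnc3ncnc(Cl)c32)c1` gives 6760 nM in this assay. Compound 3 `ClCc1ccc(Cn2cnc3c(Cl)nc(Cl)nc32)cc1` gives 95500 nM in this assay.

Compounds 1 and 3 share a core and differ by one change, (chloro in place of hydrogen on an aromatic carbon); this change gave an at least 1.0-fold lower number from compound 1 to compound 3 (0.01 log units; that floor lies within the scatter), a step whose size rests on the floor set by the limit of > 100000 nM in this assay, at which 1 of the 3 values shown sits, where compound 1 sits. Compound 2 has the same atoms as compound 1, joined differently; the difference between the two cores is not broken down here. Of the two numbers recorded, compound 2 gives the lower one, and the gap to compound 3 lies beyond the scatter.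

Compound 4 `ClCc1cccc(Cn2cnc3nc(Cl)nc(Cl)c32)c1` carries the same change made from compound 2, (chloro in place of hydrogen on an aromatic carbon). Because the earlier step of an at least 1.0-fold lower number from compound 1 to compound 3 (0.01 log units; that floor lies within the scatter) was flat, the step from compound 2 to compound 4 is expected to be a 1.0-fold lower number from compound 2 to compound 4 (0.02 log units; within the scatter), though the earlier step is anchored at a limit and so is less firm. Compound 4 is therefore estimated to give 6500 nM in this assay, expected to lie between 2500 nM and 17000 nM.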

Compound 4, concentration lethal to 50% of the cells: 7760 nM
Compound 4: the middle estimate sits 1.2-fold (0.08 log units) below what was measured, and the stated range covers the measured number.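

In this assay, chloro in place of hydrogen on an aromatic carbon, between two ring nitrogen atoms, gave a 1.1-fold higher number from compound 2 to compound 4 (0.06 log units; within the scatter), so on the core of compound 2 this change leaves the number within the scatter. Set beside the earlier step on the core of compound 1, the result allows only a loose comparison: the same change on two cores in this assay, an at least 1.0-fold lower number (0.01 log units; that floor lies within the scatter) from compound 1 to compound 3 and a 1.1-fold higher number (0.06 log units; within the scatter) from compound 2 to compound 4; the limit leaves it open whether they differ. This shows that the change is flat on the core of compound 2, but it does not show that the change carries over in the same way from one core to the other, since compound 1 stands at a limit of the assay: the limit of > 100000 nM in this assay, at which 1 of the 4 values shown sits.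

The compounds shown leave open whether an amine, a methoxy group or a longer chain in place of this chloro would read the same way on either core. They also leave open how this assay would respond if a hydroxymethyl group took the place of the chloromethyl group on the benzene ring.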